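From pyridin-2-yl to methoxy on the shared core

The source may report more compounds than this note shows. Statements on the series, on what has been measured and on what is new or still open speak of the compounds shown alone.

The shared core of compound 2 `c1ccc(-c2cccc3c2CCC3c2ncc[nH]2)nc1` carries a pyridin-2-yl group on its aromatic ring. In a functional assay on CHO cells for agonist activity at Alpha-1B adrenergic receptor (Homo sapiens), read by FLIPR and calcium flux (a lower number here means that less compound is needed, a higher number that more compound is needed for the effect), compound 2 gives only a limit, > 10000 nM. Compound 1 `Cc1ccc2c(c1NS(C)(=O)=O)CCC2c1ncc[nH]1` also reaches only a limit, > 10000 nM. Compound 3 `Clc1ccc2c(c1-c1cn[nH]c1)CCC2c1ncc[nH]1` likewise stops at a limit, > 10000 nM. So compound 2 stands where every other compound stands, namely at the limit of > 10000 nM in this assay, at which 3 of the 3 values shown sit, with no number to place it above or below its neighbours. Compound 4 `COc1cccc2c1CCC2c1ncc[nH]1` has not yet been measured; it differs from compound 2 by methoxy in place of pyridin-2-yl on an aromatic carbon. Going by the values given here, with no measured step to lean on, the step of an at least 2.0-fold lower number from compound 2 to compound 4 (0.30 log units; that floor lies within the scatter) is expected to run toward a lower number, though a limit again remains possible. Compound 4 is estimated at 5000 nM, within 500 nM to 20000 nM.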

Compound 4, half-maximal effective concentration: > 10000 nM
Compound 4 gave a limit, no number (the forecaster's own chance of this, stated with the estimate: 50%); middle value at least 2.0-fold (0.30 log units) from the limit.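

In this assay compound 4 gives > 10000 nM, which is a limit. Compound 2 also gives only a limit, so no step can be read between compound 2 and compound 4. The compounds shown leave open what number any of them would reach: the limit of > 10000 nM in this assay, at which 4 of the 4 values shown sit.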